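Ethyl to Methyl on the Shared Core: Cytotoxicity Outlook

The compounds below may be only part of what the source reports. "The series", "measured", "known", "first", "only" and "open" are said of these compounds alone.

Going by the values given here, compound 2 `CCc1nc(-c2cc(C)c(OCCC(C)CCN3CCN(c4ccnc(N)c4)C3=O)c(C)c2)no1` holds the only number so far in an ADME assay on RD cells (Homo sapiens) for cytotoxicity, read by MTT assay, with a stated time of 24 h (on this read-out lower numbers stand for higher toxicity in this test and higher numbers for lower toxicity in this test), giving 15700 nM. Compound 1 `Cc1cc(-c2noc(C(F)(F)F)n2)cc(C)c1OCCC(C)CCN1CCN(c2ccnc(N)c2)C1=O` gives > 100000 nM, which is a limit of this assay (the limit of > 100000 nM in this assay, at which 1 of the 2 values shown sits). Among the compounds with values here, the single measured step, an at least 6.3-fold lower number from compound 1 to compound 2 (0.80 log units; beyond the scatter), came from putting ethyl in place of trifluoromethyl on an aromatic carbon. Compound 3 `Cc1nc(-c2cc(C)c(OCCC(C)CCN3CCN(c4ccnc(N)c4)C3=O)c(C)c2)no1` differs from compound 2 by hydrogen in place of methyl on a saturated chain carbon bound to an aromatic carbon, a smaller change of the same kind. From that one step alone, the chemist expects a 1.6-fold higher number from compound 2 to compound 3 (0.20 log units; within the scatter), probably not reaching beyond the scatter. Compound 3 is estimated at 25000 nM, between 10000 nM and 80000 nM.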

Compound 3, half-maximal cytotoxic concentration: 28800 nM
The estimate for compound 3 lay 1.2-fold (0.06 log units) below the measured number; the range from low to high includes it.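

The change from ethyl to methyl gave a 1.8-fold higher number from compound 2 to compound 3 (0.26 log units; within the scatter), so in this assay these two groups cannot be told apart at this position. Methyl in place of trifluoromethyl still gave an at least 3.4-fold lower number from compound 1 to compound 3 (0.54 log units; beyond the scatter), which shows that the separation from trifluoromethyl is not confined to ethyl. The value of compound 1 is a limit, so the full size of that step stays unknown: the limit of > 100000 nM in this assay, at which 1 of the 3 values shown sits.

As far as these compounds go, it remains open where a longer chain such as propyl, or an amine, would fall in this test at this position.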